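This account rests on a few compounds, and the source may have more. Where it says the series, first, only, none or still open, it means among the compounds named here.

Measured in a functional assay on HeLa cells (Homo sapiens) for inhibition, with a stated time of 72 h; a higher number here means a weaker inhibitor, a lower number a stronger inhibitor:
- Compound 1 `CCCCNC(=O)C1(N(Cc2ccccc2)C(=O)[C@H](CC(=O)OC)NC(=O)OC(C)(C)C)CCN(Cc2ccccc2)CC1`: 36000 nM
- Compound 2 `COC(=O)C[C@H](NC(=O)OC(C)(C)C)C(=O)N(Cc1ccccc1)C1(C(=O)NC2CCCCC2)CCN(Cc2ccccc2)CC1`: 21000 nM
- Compound 3 `COC(=O)C[C@H](NC(=O)OC(C)(C)C)C(=O)N(Cc1ccc(F)cc1)C1(C(=O)NCc2ccccc2)CCN(Cc2ccccc2)CC1`: 19000 nM

All three values lie within the scatter of one another, so compound 3, at 19000 nM, stands apart from neither compound 1 nor compound 2. Compound 4 `CCC(C)N(C(=O)[C@H](CC(=O)OC)NC(=O)OC(C)(C)C)C1(C(=O)NCc2ccccc2)CCN(Cc2ccccc2)CC1` follows from compound 3 with sec-butyl in place of 4-fluorobenzyl on an amide-type nitrogen. Going by the values given here, only one measured step offers guidance, a 1.7-fold lower number from compound 1 to compound 2 (0.23 log units; within the scatter), and it stayed within the scatter. Among the compounds with values here, that step exchanges other groups, so the data hold no direct precedent for this change. No shift beyond the scatter is therefore expected in this assay, and no direction can be favoured with confidence. The expected change is a 1.3-fold higher number from compound 3 to compound 4 (0.12 log units; within the scatter). For compound 4 the estimated value is 25000 nM, with an expected range of 10000 nM to 60000 nM.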

Compound 4, half-maximal inhibitory concentration: 16000 nM
The estimate for compound 4 lay 1.6-fold (0.19 log units) above the measured number; measured number inside the range.
By their numbers in this assay, from the lowest: compounds 4, 3, 2 and 1 (each within the scatter of the next, the first and the last beyond it).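

In this assay sec-butyl in place of 4-fluorobenzyl on the amide-type nitrogen gives a 1.2-fold lower number from compound 3 to compound 4 (0.07 log units; within the scatter) and so, at this position, a group with no ring stands level with one bearing a six-membered aromatic ring. Going by these compounds alone, this is the first direct look at this nitrogen, and it shows that the aromatic ring is not needed to keep the number at this level. No supporting evidence bears on this result. Still open, as far as these compounds go, is whether an amine or a carboxylic acid on this nitrogen would shift the number beyond the scatter.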